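Lengthening the sulfur chain on a selenium-containing antiproliferative core

The compounds below may be only part of what the source reports. "The series", "measured", "known", "first", "only" and "open" are said of these compounds alone.

Compound 1 `CC(C)Sc1n[nH]c(-n2[se]c3ccccc3c2=O)n1` is a weak inhibitor in a functional assay on HeLa cells (Homo sapiens) for antiproliferative activity, read by CCK-8 assay, with a stated time of 48 h (a lower number here means a stronger inhibitor, a higher number a weaker inhibitor), where compound 1 gives 34600 nM. Among the measured compounds shown here, that is the highest of the two numbers measured so far; compound 2 `O=c1c2ccccc2[se]n1-c1nc(SCc2ccc([N+](=O)[O-])cc2)n[nH]1`, which carries a different group on the sulfur, gives 3940 nM in this assay, a clearly lower number, so compound 2 is the stronger inhibitor of the two. For the measured compounds named here, no single-point step between measured compounds exists here, so the two values stand on their own.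

Compound 3 `CCCCCSc1n[nH]c(-n2[se]c3ccccc3c2=O)n1` keeps the core of compound 1 and differs in one place: pentyl in place of isopropyl on a sulfur A straight five-carbon chain replaces a branched three-carbon one, with donors, acceptors and charge unchanged. Going by the values given here, with no comparable step on record, the expected change for compound 3 in this assay is small and of uncertain direction, estimated as a 1.6-fold lower number from compound 1 to compound 3 (0.20 log units; within the scatter), giving an expected value of about 22000 nM within a range from 8000 nM to 60000 nM.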

Compound 3, half-maximal inhibitory concentration: 30300 nM
The estimate for compound 3 lay 1.4-fold (0.14 log units) below the measured number; the range from low to high includes it.
By their numbers in this assay, from the lowest: compound 2; then compounds 3 and 1 (each within the scatter of the next).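

Swapping isopropyl for pentyl on this sulfur makes no real difference in this assay (a 1.1-fold lower number from compound 1 to compound 3 (0.06 log units; within the scatter)), a step that stays within the scatter. So this added chain length, along with the loss of the branch, does not bring compound 3 near compound 2 (3940 nM), which remains clearly the stronger inhibitor of the three. Nothing measured here explains why the chain swap leaves the number in place.

On these data alone, what the different group on the sulfur of compound 2 contributes remains open, and a plain benzyl group at this position, without the nitro group, would help separate the roles of the ring and the nitro group. As far as these compounds go, whether a longer chain, such as decyl, would move the number also remains unknown.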